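Swapping methoxy for fluoro on the shared core

The source may hold more compounds than are shown below. What is called first, only, known or untested is meant among the compounds shown, and "the series" means these compounds.

Of the compounds shown here, three built on a shared core have been tested in a functional assay on SK-MEL-28 cells (Homo sapiens) for inhibition, read by sulforhodamine B assay, with a stated time of 48 h; a lower number here means a stronger inhibitor of growth, a higher number a weaker inhibitor of growth. Compound 1, `CCOC(=O)[C@H](CCC(=O)O)NC(=O)c1ccc(Sc2nc3cc(N)cc(N)c3nc2-c2ccccc2)cc1`, gives 6760 nM. Compound 2, `COc1cc(CNc2nc3cc(N)cc(N)c3nc2-c2ccccc2)cc(OC)c1OC`, gives 8510 nM. Compound 3, `COc1ccc(Sc2nc3cc(N)cc(N)c3nc2-c2ccccc2)cc1`, gives 24500 nM, the highest of the three numbers; its gap to compound 2 and its larger gap to compound 1 both lie beyond the usual scatter, so among these three compound 3 is the weakest inhibitor of growth.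

Compound 4, `Nc1cc(N)c2nc(-c3ccccc3)c(Sc3ccc(F)cc3)nc2c1`, has not yet been measured. It differs from compound 3 in one place: fluoro in place of methoxy on an aromatic carbon. Among the compounds with values here, no pair among the measured compounds differs by this kind of change, so there is no earlier step to lean on; the two groups are both small and sit on the same aromatic carbon, which gives little ground to expect a large shift in either direction.

The step expected in this assay from compound 3 to compound 4 is a 1.4-fold lower number from compound 3 to compound 4 (0.13 log units; within the scatter), that is, no change beyond the scatter. Compound 4 is therefore estimated at 18000 nM, with a range from 6000 nM to 55000 nM.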

Compound 4, concentration for 50% growth inhibition: 23400 nM
Beside the measured number, compound 4's estimate is 1.3-fold (0.11 log units) below it; measured number inside the range.
By their numbers in this assay, from the lowest: compounds 1 and 2 (each within the scatter of the next); then compounds 4 and 3 (each within the scatter of the next).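

In this assay the exchange of (4-methoxyphenyl)sulfanyl for (4-fluorophenyl)sulfanyl gives a 1.0-fold lower number from compound 3 to compound 4 (0.02 log units; within the scatter) and so provides the first direct reading of a single change among these compounds. At this place, para to a large group, the read-out does not separate methoxy from fluoro, even though the methoxy counts one hydrogen-bond acceptor and the fluoro none, and the fluoro is the smaller group by heavy atoms. Nothing available bears on why the number stays put, so the result stands as an observation only.

The compounds shown leave open whether an amine or a carboxylic acid at this same place would also leave the number within the scatter, or whether it would move clearly in one direction, and the same question applies to a longer chain such as ethoxy. They also leave open whether fluoro in place of methoxy would remain just as silent on a different carbon of that ring, since this single pair speaks for one place alone.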